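This account rests on a few compounds, and the source may have more. Where it says the series, first, only, none or still open, it means among the compounds named here.

Measured in a functional assay on HT-29 cells (Homo sapiens) for inhibition, read by MTT assay, with a stated time of 48 h; on this read-out higher numbers stand for weaker inhibition and lower numbers for stronger inhibition:
Compound 1 `COc1cc(-c2nnc(SCc3ccccc3)n2-c2ccc(N(C)C)cc2)cc(OC)c1OC`: > 60000 nM, a limit
Compound 2 `COc1ccc(CSc2nnc(-c3cc(OC)c(OC)c(OC)c3)n2-c2ccc(N(C)C)cc2)cc1`: > 60000 nM, a limit
Compound 3 `COc1cc(-c2nnc(SCC(=O)c3ccc(F)cc3)n2-c2ccc(N(C)C)cc2)cc(OC)c1OC`: 78100 nM

Compound 3, at 78100 nM, holds the only actual number among these. Compound 1 and compound 2 stand at the limit of > 60000 nM in this assay, at which 2 of the 3 values shown sit. Compound 4 `COc1cc(-c2nnc(SCC(=O)C3CC3)n2-c2ccc(N(C)C)cc2)cc(OC)c1OC` keeps the rest of compound 3 and carries cyclopropyl in place of 4-fluorophenyl on a carbonyl carbon. Two measured steps alter this part of the molecule, a step that the limit leaves unreadable from compound 1 to compound 3 and a step that the limit leaves unreadable from compound 2 to compound 3, and neither yields a size. With no readable step to draw on, only a small shift is expected, a 1.0-fold lower number from compound 3 to compound 4 (0.02 log units; within the scatter). For compound 4 the estimated value is 75000 nM, with an expected range from 35000 nM to 160000 nM.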

Compound 4, half-maximal inhibitory concentration: > 60000 nM
Compound 4: no number, only a limit; the forecaster's own chance of this, stated with the estimate: 50%; the middle value is on the limit's open side.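

Compound 4 gives > 60000 nM, which is a limit and not a number. None of the steps linking compound 1, compound 2, compound 3 and compound 4 can be read. On these data alone, whether cyclopropyl or 4-fluorophenyl on the carbonyl carbon gives stronger inhibition remains open.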